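Working notes: phenyl in place of cyano

The source may hold more compounds than are shown below. What is called first, only, known or untested is meant among the compounds shown, and "the series" means these compounds.

Compound 2 `N#Cc1ccc(-c2cc3c(n2-c2ccc(O)c(C(=O)O)c2)CCCC3)cc1` gives 0% in a functional assay on the whole organism (strain Wistar) for inhibition, with Rattus norvegicus as the target, read by paw edema, with stated times of 30 min and 3 h, at a dose of 200 mg/kg by the oral route (on this read-out lower numbers stand for less inhibition and higher numbers for more inhibition at the one dose given (going by the name of the read-out)), the lowest of the two numbers obtained so far. Its nearest neighbour is compound 1 `COc1ccc(-c2cc3c(n2-c2ccc(O)c(C(=O)O)c2)CCCC3)cc1`, which gives 50% in this assay; the step of a number 50 percentage points lower from compound 1 to compound 2 (beyond the scatter) is large and lies beyond the scatter. Compound 3 `O=C(O)c1cc(-n2c(-c3ccc(-c4ccccc4)cc3)cc3c2CCCC3)ccc1O` has not yet been measured. It differs from compound 2 in one place: phenyl in place of cyano on an aromatic carbon. Among the compounds with values here, no measured step exchanges cyano for phenyl, so the only step that bears on this change is a number 50 percentage points lower from compound 1 to compound 2 (beyond the scatter), which shows that the group at this place moves the read-out strongly. Compound 2 gives 0%, which leaves no room for a further fall, so any step beyond the scatter from compound 2 to compound 3 can only be upward. The step from compound 2 to compound 3 in this assay is therefore expected to be a number 30 percentage points higher from compound 2 to compound 3 (beyond the scatter), upward, with wide uncertainty. Compound 3 is estimated to give 30% in this assay, with a range from 5% to 60%.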

Compound 3, a percentage reported as inhibition, in the whole organism at one dose (the size of the read-out at that dose, not a potency): 50%
For compound 3 the middle estimate is 20 percentage points below the measured one, and the stated range covers the measured number.
By their numbers in this assay, from the lowest: compound 2; then compounds 1 and 3 (each within the scatter of the next).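

In this assay, phenyl in place of cyano gives a number 50 percentage points higher from compound 2 to compound 3 (beyond the scatter), so this position, on an aromatic carbon para to a large group, accepts a six-membered aromatic ring of carbon only without the loss seen with the nitrile. Phenyl in place of methoxy gives no change at the digits printed from compound 1 to compound 3 (within the scatter), so the read-out does not separate these two groups at this dose, and among the three groups shown only cyano stands apart from the other two. Nothing measured on these compounds bears on what sets cyano apart, and the step remains an observation without an assigned cause.

The three compounds leave open whether any group at this place can lift the read-out past the level shared by compound 1 and compound 3, or whether that level is a ceiling for the series at this dose; an amine, a carboxylic acid or a longer chain such as butoxy would test this. With a single dose, the equal read-outs of compound 1 and compound 3 also say nothing on whether the two would stay level at other doses.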